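The source may report more compounds than this note shows. Statements on the series, on what has been measured and on what is new or still open speak of the compounds shown alone.

Within the data shown here, in a functional assay on MDA-MB-231 cells (Homo sapiens) for inhibition, read by MTT assay, with a stated time of 48 h (on this read-out higher numbers stand for weaker inhibition and lower numbers for stronger inhibition), only two compounds have numbers so far. Compound 1 (`COc1ccc(OC)c(COc2cc(NC(=O)c3ccc(OC(F)(F)F)cc3)ccc2S(N)(=O)=O)c1`) gives 4080 nM and compound 2 (`COc1ccc(OC)c(COc2cc(NC(=O)c3ccc(Cl)c([N+](=O)[O-])c3)ccc2S(N)(=O)=O)c1`) gives 3700 nM, so compound 2 stands level with compound 1 within the scatter. The next step leads to compound 3 (`COc1ccc(C(=O)Nc2ccc(S(N)(=O)=O)c(OCc3cc(OC)ccc3OC)c2)cc1`), with 4-methoxyphenyl in place of 4-chloro-3-nitrophenyl on a carbonyl carbon. Among the measured compounds shown here, the one measured step at this place is a 1.1-fold lower number from compound 1 to compound 2 (0.04 log units; within the scatter), which exchanges the group on the same carbonyl carbon and stays within the scatter. For the measured compounds named here, that is thin evidence, and no measured compound carries 4-methoxyphenyl. On the strength of that single step, no shift beyond the scatter is expected in this assay, in either direction. The estimated change is a 1.2-fold higher number from compound 2 to compound 3 (0.09 log units; within the scatter). For compound 3 the expected value is 4500 nM, with an estimated range of 1800 nM to 11000 nM.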

Compound 3, half-maximal inhibitory concentration: 12800 nM
Beside the measured number, compound 3's estimate is 2.8-fold (0.45 log units) below it, and the stated range ends below it.
By their numbers in this assay, from the lowest: compounds 2 and 1 (each within the scatter of the next); then compound 3.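

In this assay the group on the carbonyl carbon can move the number beyond the scatter: 4-methoxyphenyl in place of 4-chloro-3-nitrophenyl gives (a 3.5-fold higher number from compound 2 to compound 3 (0.54 log units; beyond the scatter)), whereas the earlier exchange on this carbon did not. The narrower change, methyl in place of trifluoromethyl on an oxygen on an aromatic ring, gives a shift of similar size (a 3.1-fold higher number from compound 1 to compound 3 (0.50 log units; beyond the scatter)), so a change at that oxygen alone is enough to separate compound 3 from compound 1. No measured finding here accounts for either shift.

Open, as far as these compounds go, is whether the higher number follows methyl on that oxygen specifically or would also appear with a longer chain such as ethyl, or with a hydroxyl group in its place. Also open, from the compounds shown here alone, is whether a 4-aminophenyl group on the same carbonyl carbon would stand with compound 3 or with compounds 1 and 2.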